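This account rests on a few compounds, and the source may have more. Where it says the series, first, only, none or still open, it means among the compounds named here.

Compound 1 `COc1cc(/C=N/Nc2nc(-c3ccc(Br)cc3)cs2)cc(Br)c1OC` gives 52300 nM in a functional assay on A549 cells (Homo sapiens) for inhibition, read by MTT assay, with a stated time of 48 h; on this read-out lower numbers stand for stronger inhibition and higher numbers for weaker inhibition. Compound 3 `COc1cc(/C=N/Nc2nc(-c3ccc(Br)cc3)cs2)c(Br)c(Br)c1OC` gives 46100 nM, compound 2 `Fc1ccc(/C=N/Nc2nc(-c3ccccc3)cs2)cc1F` gives 91400 nM, and the three numbers all lie within the usual scatter of one another, so compound 1 sits among them without separation. Compound 4 `COc1cc(/C=N/Nc2nc(-c3ccccc3)cs2)cc(Br)c1OC` differs from compound 1 by hydrogen in place of bromo on an aromatic carbon. Among the compounds with values here, no measured step removes this bromo; the one measured step, a 1.1-fold lower number from compound 1 to compound 3 (0.05 log units; within the scatter), adds a bromo at another place and stays within the scatter, and compound 2, which carries the phenyl, shows a number within the scatter of compound 1. No step beyond the scatter is therefore expected in this assay for compound 4. Compound 4 is expected near 55000 nM, between 25000 nM and 120000 nM. The expected step is a 1.1-fold higher number from compound 1 to compound 4 (0.02 log units; within the scatter).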

Compound 4, half-maximal inhibitory concentration: 40000 nM
Compound 4: the middle estimate sits 1.4-fold (0.14 log units) above what was measured; low and high end bracket the measured number.
By their numbers in this assay, from the lowest: compounds 4, 3, 1 and 2 (each within the scatter of the next, the first and the last beyond it).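

The change from 4-bromophenyl to phenyl gives a 1.3-fold lower number from compound 1 to compound 4 (0.12 log units; within the scatter) in this assay, so at this place on the ring the bromo can be lost without a step beyond the scatter. Together with a 1.1-fold lower number from compound 1 to compound 3 (0.05 log units; within the scatter), this leaves both single bromo changes read so far within the scatter, at numbers that show only weak inhibition. On these data alone, whether an amine or a carboxylic acid at this place would move the number beyond the scatter stays open, as does whether the same change behaves alike with other groups on the shared core. No measurement on hand explains this result.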